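This account rests on a few compounds, and the source may have more. Where it says the series, first, only, none or still open, it means among the compounds named here.

Measured compounds:
- compound 1, `COc1cc(OC)c2c(=O)cc(-c3ccccc3Cl)oc2c1CN1CCCCC1`, in a functional assay on A549 cells (Homo sapiens) for antiproliferative activity, with a stated time of 72 h (on this read-out lower numbers stand for stronger inhibition and higher numbers for weaker inhibition), compound 1 gives only a limit, > 150000 nM.
- compound 2, `COc1cc(OC)c(C(=O)/C=C/c2ccccc2Cl)c(O)c1CN(C)CCCN(C)C`, compound 2 gives 3100 nM.
- compound 3, `CCN(CC)Cc1c(OC)cc(OC)c(C(=O)/C=C/c2ccccc2Cl)c1O`, compound 3 gives 3600 nM.

Compound 3 stands at the highest of the two numbers shown, with compound 2 as its nearest neighbour; the two values lie within the scatter of one another. Compound 4, `COc1cc(OC)c(C(=O)/C=C/c2ccccc2Cl)c(O)c1CN(C)C`, differs from compound 3 by dimethylamino in place of diethylamino on a saturated chain carbon bound to an aromatic carbon. For the measured compounds named here, one measured step bears on this change: a 1.2-fold higher number from compound 2 to compound 3 (0.06 log units; within the scatter), where one amine on the same saturated chain carbon was exchanged for another without moving the number beyond the scatter. The exchange of diethylamino for dimethylamino is a smaller change of the same kind, so no step beyond the scatter is expected in this assay, in either direction. The estimate for compound 4 is therefore 3500 nM, expected to fall between 1500 nM and 8000 nM, which means an expected step of a 1.0-fold lower number from compound 3 to compound 4 (0.01 log units; within the scatter).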

Compound 4, half-maximal inhibitory concentration: 2100 nM
For compound 4 the middle estimate is 1.7-fold (0.22 log units) above the measured one; the measured number falls inside the stated range.
By their numbers in this assay, from the lowest: compounds 4, 2 and 3 (each within the scatter of the next). At a limit, above all of these: compound 1.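

In this assay, the step of a 1.7-fold lower number from compound 3 to compound 4 (0.23 log units; within the scatter) shows that the diethylamino group on this saturated chain carbon bound to an aromatic carbon can be exchanged for dimethylamino without the number leaving the scatter. Compound 4 also lacks the 2-(dimethylamino)ethyl group of compound 2, and the step of a 1.5-fold lower number from compound 2 to compound 4 (0.17 log units; within the scatter) again stays within the scatter, so the three amines in compounds 2, 3 and 4 give values that cannot be told apart in this assay. Nothing available here bears on the response to this change.

All three of these compounds carry an open-chain tertiary amine on this carbon. On these data alone, whether a morpholine, a primary amine or a carboxylic acid in its place would give a similar number remains open.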